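Notes on the ring amide change toward compound 4

The source may hold more compounds than are shown below. What is called first, only, known or untested is meant among the compounds shown, and "the series" means these compounds.

Measured in an ADME assay on cells (Hepatocyte, Homo sapiens) for metabolic stability, read by LC-MS, tested at 1 uM (on this read-out lower numbers stand for slow clearance and higher numbers for fast clearance), so far:
- compound 1 `Cc1cc(COc2ccc(S(=O)(=O)N(C)C3(C(=O)NO)CN(C(=O)C(C)C)C3)cc2)c2ccccc2n1`: 8 uL/min
- compound 2 `CCN(C1(C(=O)NO)CN(C(=O)C(C)C)C1)S(=O)(=O)c1ccc(OCc2cc(C)nc3ccccc23)cc1`: 11 uL/min
- compound 3 `Cc1cc(COc2ccc(S(=O)(=O)N(C(C)C)C3(C(=O)NO)CN(C(=O)C(C)C)C3)cc2)c2ccccc2n1`: 17 uL/min

Compound 1 stands at the lowest of the three numbers. Its nearest neighbour is compound 2, with a 1.4-fold higher number from compound 1 to compound 2 (0.14 log units; within the scatter); its furthest is compound 3, with a 2.1-fold higher number from compound 1 to compound 3 (0.33 log units; beyond the scatter). Between the other two, a 1.5-fold higher number from compound 2 to compound 3 (0.19 log units; within the scatter). Among the compounds with values here, every measured step so far sits on the sulfonamide nitrogen or on the chain carbon bound to it.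

The change toward compound 4 `Cc1cc(COc2ccc(S(=O)(=O)N(C)C3(C(=O)NO)CN(C(=O)CC(C)C)C3)cc2)c2ccccc2n1` lies elsewhere, on the carbonyl carbon whose other neighbour is the amide-type nitrogen in a ring: isobutyl in place of isopropyl on a carbonyl carbon. Within the data shown here, none of the measured steps touches this position, so there is no direct precedent. The indirect guide is that the step adding two carbons on the sulfonamide nitrogen was modest, while each one-carbon step stayed within the scatter. A one-carbon enlargement of the acyl group is therefore expected to move the number in this assay little, most likely upward by an amount within the scatter, with the step expected to be a 1.4-fold higher number from compound 1 to compound 4 (0.14 log units; within the scatter). The estimate for compound 4 in this assay is 11 uL/min, with a range from 6 uL/min to 22 uL/min.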

Compound 4, intrinsic clearance in a liver preparation (reported as CLH), per the amount of preparation that the assay uses: 14 uL/min
For compound 4 the middle estimate is 1.3-fold (0.10 log units) below the measured one; low and high end bracket the measured number.
By their numbers in this assay, from the lowest: compounds 1, 2, 4 and 3 (each within the scatter of the next, the first and the last beyond it).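

Within the data shown here, on the carbonyl carbon whose other neighbour is the amide-type nitrogen in a ring, isobutyl in place of isopropyl gives a 1.8-fold higher number from compound 1 to compound 4 (0.24 log units; within the scatter) in this assay, the first reading at a position that the earlier steps left untouched. On this read-out, the isopropylcarbonyl to isobutylcarbonyl change therefore cannot be told apart from repeat measurement, as also holds for the step on the saturated chain carbon bound to a sulfonamide nitrogen, a 1.4-fold higher number from compound 1 to compound 2 (0.14 log units; within the scatter). No measurement at hand bears on what lies behind the new step, so it stands as an observation only.

This single pair leaves open whether the position stays as flat in this assay with a longer chain on the carbonyl carbon, or with an acyl group carrying an amine or a carboxylic acid. It also leaves open whether isobutyl in place of isopropyl gives a similar step when the sulfonamide nitrogen carries the isopropyl of compound 3 rather than the methyl of compound 1.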